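Aryl substituent change on the anilino group of the shared core

This account rests on a few compounds, and the source may have more. Where it says the series, first, only, none or still open, it means among the compounds named here.

Measured compounds:
compound 1 `FC(F)(F)c1ccc(CSc2nc(Nc3ccccc3)c3ccccc3n2)cc1` — 20000 nM
compound 2 `Cc1ccc(Nc2nc(SCc3ccc(C(F)(F)F)cc3)nc3ccccc23)cc1` — 21100 nM

Both measured compounds were tested in a functional assay on PC-3 cells (Homo sapiens) for cytotoxicity, read by MTT assay, with a stated time of 72 h; a higher number here means a weaker inhibitor, a lower number a stronger inhibitor. Compound 1 gives 20000 nM and compound 2 gives 21100 nM. Within the data shown here, the single measured step, a 1.1-fold higher number from compound 1 to compound 2 (0.02 log units; within the scatter), is the replacement of hydrogen by methyl on an aromatic carbon and changes nothing beyond the scatter. Compound 2 therefore has the highest of the two numbers, but it cannot be separated from compound 1 on these data.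

Compound 3 `COc1ccc(Nc2nc(SCc3ccc(C(F)(F)F)cc3)nc3ccccc23)c(OC)c1` is not yet measured. It differs from compound 2 as follows: 2,4-dimethoxyphenyl in place of 4-methylphenyl on a nitrogen on an aromatic ring. Among the measured compounds shown here, the only measured step bears on it indirectly, showing that a small change on the aryl ring attached to the nitrogen left this assay unchanged within the scatter. For the measured compounds named here, no measured step covers methoxy groups or a second substituent on that ring, so nothing in the data argues for a change beyond the scatter in either direction. Compound 3 is therefore expected to sit near compound 2, with a step of a 1.1-fold lower number from compound 2 to compound 3 (0.02 log units; within the scatter). The estimate for compound 3 is 20000 nM, within the range 7000 nM to 60000 nM.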

Compound 3, half-maximal inhibitory concentration: 32500 nM
Estimate against measurement, compound 3: 1.6-fold (0.21 log units) below; measured number inside the range.
By their numbers in this assay, from the lowest: compounds 1, 2 and 3 (each within the scatter of the next).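

In this assay, the position on a nitrogen on an aromatic ring now has a larger change behind it than the single methyl of the earlier step. 2,4-Dimethoxyphenyl in place of 4-methylphenyl gives a 1.5-fold higher number from compound 2 to compound 3 (0.19 log units; within the scatter), and 2,4-dimethoxyphenyl in place of phenyl gives a 1.6-fold higher number from compound 1 to compound 3 (0.21 log units; within the scatter). Both steps stay within the scatter, so this position accepts methoxy groups, a second ring substituent and the hydrogen-bond acceptors counted for 2,4-dimethoxyphenyl without a readable shift, and the three compounds cannot be separated on these numbers. No evidence on this result is available here.

Open, as far as these compounds go, is whether any group at this position can move the number beyond the scatter, for example an amine or a carboxylic acid on the aryl ring, or a longer chain in place of that ring. Also open, from the compounds shown here alone, is what a nitrile or a carboxylic acid in place of the trifluoromethyl group, which all three compounds share, would do.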